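The source may report more compounds than this note shows. Statements on the series, on what has been measured and on what is new or still open speak of the compounds shown alone.

Of the compounds shown here, three built on one shared core have been tested in a functional assay on PANC-1 cells (Homo sapiens) for inhibition, read by MTT assay, with a stated time of 24 h; a lower number here means a stronger inhibitor, a higher number a weaker inhibitor. Compound 1 `CC1(C)[C@H]2CC[C@]1(C)N(Cc1cn(-c3ccccc3O)nn1)C(=O)C2` gives 230 nM. Compound 2 `CC1(C)[C@H]2CC[C@]1(C)N(Cc1cn(-c3ccc(F)cc3)nn1)C(=O)C2` gives 110 nM. Compound 3 `CC1(C)[C@H]2CC[C@]1(C)N(Cc1cn(-c3cccc(O)c3)nn1)C(=O)C2` gives 280 nM, the highest of the three numbers, although its nearest neighbour, compound 1, sits only a 1.2-fold higher number from compound 1 to compound 3 (0.09 log units; within the scatter) away, and the wider gap is the step of a 2.5-fold higher number from compound 2 to compound 3 (0.41 log units; beyond the scatter).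

The next compound, compound 4 `CC1(C)[C@H]2CC[C@]1(C)N(Cc1cn(-c3ccc(O)cc3)nn1)C(=O)C2`, differs from compound 3 in one place: 4-hydroxyphenyl in place of 3-hydroxyphenyl on an aromatic nitrogen. Of the measured steps, the one that bears most directly on this change is a 1.2-fold higher number from compound 1 to compound 3 (0.09 log units; within the scatter), since it too exchanges one hydroxyphenyl group for another and the result stayed within the scatter. The other two steps, a 2.1-fold lower number from compound 1 to compound 2 (0.32 log units; beyond the scatter) and a 2.5-fold higher number from compound 2 to compound 3 (0.41 log units; beyond the scatter), swap a hydroxyphenyl group for a fluorophenyl group and so speak less to the present change, though they show that such swaps can shift this assay modestly. On this basis no step beyond the scatter is expected for a 1.1-fold lower number from compound 3 to compound 4 (0.05 log units; within the scatter), with the number for compound 4 estimated at 250 nM, most plausibly between 120 nM and 550 nM.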

Compound 4, half-maximal inhibitory concentration: 100 nM
Compound 4: the middle estimate sits 2.5-fold (0.40 log units) above what was measured; the whole stated range lies above it.
By their numbers in this assay, from the lowest: compounds 4 and 2 (each within the scatter of the next); then compounds 1 and 3 (each within the scatter of the next).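

Where the hydroxy group sits on this ring matters in this assay: the earlier exchange of one hydroxyphenyl for another stayed within the scatter, but 4-hydroxyphenyl in place of 3-hydroxyphenyl gives a 2.8-fold lower number from compound 3 to compound 4 (0.45 log units; beyond the scatter) and 4-hydroxyphenyl in place of 2-hydroxyphenyl gives a 2.3-fold lower number from compound 1 to compound 4 (0.36 log units; beyond the scatter) as well. Compounds 1 and 3 alone could not show this: the same atoms, joined differently, can move the number beyond the scatter when the group on the aromatic nitrogen is changed. Hydroxy in place of fluoro on an aromatic carbon gives a 1.1-fold lower number from compound 2 to compound 4 (0.04 log units; within the scatter) and so makes no difference that can be read, which leaves compounds 2 and 4 together, apart from compounds 1 and 3.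

Going by these compounds, whether a different group on this phenyl ring, such as an amine, a methoxy group or a carboxylic acid, would read with compounds 2 and 4 or with compounds 1 and 3 remains open. Nothing measured here explains why the 4-hydroxyphenyl group differs from the other two hydroxyphenyl groups.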